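The source may report more compounds than this note shows. Statements on the series, on what has been measured and on what is new or still open speak of the compounds shown alone.

Measured compounds:
- compound 1, `COc1cccc(OC)c1C(=O)Nc1c[nH]nc1C(=O)NC1CCN(Cc2ccccc2)C1`: 38000 nM
- compound 2, `CO[C@H]1CC[C@H](NC(=O)c2n[nH]cc2NC(=O)c2ncoc2-c2ccccc2)CC1`: 28000 nM
- compound 3, `COc1cccc(OC)c1C(=O)Nc1c[nH]nc1C(=O)NC1CCC1`: > 50000 nM

All three have been tested in an ADME assay on MRC5 cells (Homo sapiens) for inhibition, with a stated time of 72 h; a higher number here means that more compound is needed for the effect, a lower number that less compound is needed. Compound 1 gives 38000 nM and compound 2 gives 28000 nM; these two values lie within the usual scatter of each other, so no order between them can be claimed. For compound 3 the assay reports only a limit, > 50000 nM, and not a number. Going by these compounds, compound 3 therefore stands at the limit of > 50000 nM in this assay, at which 1 of the 3 values shown sits, and how far beyond that limit it lies is unknown.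

Compound 4, `COc1cccc(OC)c1C(=O)Nc1c[nH]nc1C(=O)NC1CCCCCC1`, has not yet been measured. It differs from compound 3 in a single place: cycloheptyl in place of cyclobutyl on an amide-type nitrogen. Among the compounds with values here, no pair of measured compounds shows this change, so its effect in this assay cannot be read from the data. Within the data shown here, with no step of this kind on record, compound 4 is expected to remain near where compound 3 sits, with an estimated step of an at least 1.1-fold lower number from compound 3 to compound 4 (0.04 log units; that floor lies within the scatter). Compound 4 is thus estimated at 45000 nM, with a range from 18000 nM to 100000 nM, and a fair chance that only a limit is reported again.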

Compound 4, half-maximal effective concentration: 42000 nM
Compound 4: the middle estimate sits 1.1-fold (0.03 log units) above what was measured; the measured number falls inside the stated range.
By their numbers in this assay, from the lowest: compounds 2, 1 and 4 (each within the scatter of the next). At a limit, above all of these: compound 3.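

In this assay, within the data shown here, replacing cyclobutyl with cycloheptyl on an amide-type nitrogen gives an at least 1.1-fold lower number from compound 3 to compound 4 (0.07 log units; that floor lies within the scatter), the first step on record at this position. Going by these compounds, since that step is only a floor, its true size stays unknown, but the change does turn a result with no number into a measured one, and the larger all-carbon ring is tolerated here without the value leaving the range of the other measured compounds. Compound 3 is still reported only as a limit, the single such case among the compounds shown: the limit of > 50000 nM in this assay, at which 1 of the 4 values shown sits.

The compounds shown leave open how cyclopentyl or cyclohexyl would read at this place, and whether a ring carrying an amine or a carboxylic acid would read differently from these plain carbon rings. Also open, on these data alone, is whether the same change would give a similar result on the core of compound 2.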